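Chain-length and terminal-group variants in a quinolinone cytotoxicity series

The source may hold more compounds than are shown below. What is called first, only, known or untested is meant among the compounds shown, and "the series" means these compounds.

Three measured compounds share one core and differ only in the chain carried on the aromatic nitrogen. Compound 1 `COc1ccc(-c2cc3c(OC)cc(OC)cc3n(CC#N)c2=O)cc1` carries the shortest chain and in a functional assay on LoVo cells (Homo sapiens) for cytotoxicity, read by colorimetric assay and MTT assay (on this read-out higher numbers stand for weaker inhibition and lower numbers for stronger inhibition), compound 1 gives 10000 nM. Compound 2 `COc1ccc(-c2cc3c(OC)cc(OC)cc3n(CC(=O)OCc3ccccc3)c2=O)cc1` differs from it by benzyloxycarbonyl in place of cyano on a saturated chain carbon bound to an aromatic nitrogen and in this assay compound 2 gives 10000 nM, so that no change at the digits printed from compound 1 to compound 2 (within the scatter). Compound 3 `COc1ccc(-c2cc3c(OC)cc(OC)cc3n(CCC#N)c2=O)cc1` differs from compound 1 by cyanomethyl in place of cyano on a saturated chain carbon bound to an aromatic nitrogen and in this assay compound 3 gives 10000 nM; the step of no change at the digits printed from compound 1 to compound 3 (within the scatter) and the step of no change at the digits printed from compound 2 to compound 3 (within the scatter) are both flat. None of the three chain variants moves the read-out at the digits recorded.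

Compound 4 `COc1ccc(-c2cc3c(OC)cc(OC)cc3n(CCC(=O)OCc3ccccc3)c2=O)cc1` is not yet measured. It differs from compound 3 by benzyloxycarbonyl in place of cyano on a saturated chain carbon, two bonds along the chain from an aromatic nitrogen. Among the compounds with values here, this is the same kind of change as the one from compound 1 to compound 2, but not the same: in that pair the group sits on a saturated chain carbon bound to an aromatic nitrogen, whereas in compound 4 it sits on a saturated chain carbon, two bonds along the chain from an aromatic nitrogen. The difference between the two cores is covered by the change from compound 1 to compound 3 given above.

Because no change at the digits printed from compound 1 to compound 2 (within the scatter) and because no change at the digits printed from compound 1 to compound 3 (within the scatter), the expectation is that compound 4 will also sit level with the others, with an estimated step of no change at the digits printed from compound 3 to compound 4 (within the scatter). In this assay compound 4 is expected at 10000 nM, estimated to lie between 5000 nM and 20000 nM.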

Compound 4, half-maximal inhibitory concentration: 10000 nM
The estimate for compound 4 equals the measured number at the digits printed, within the range that was stated.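

Benzyloxycarbonyl in place of cyano on a saturated chain carbon, two bonds along the chain from an aromatic nitrogen, gives in this assay no change at the digits printed from compound 3 to compound 4 (within the scatter), and the other two new steps read the same way, with no change at the digits printed from compound 2 to compound 4 (within the scatter) and no change at the digits printed from compound 1 to compound 4 (within the scatter). The same change thus reads alike on the two cores: the same change on two cores in this assay, no change at the digits printed (within the scatter) from compound 1 to compound 2 and no change at the digits printed (within the scatter) from compound 3 to compound 4, 1.0-fold (0.00 log units) apart, within the scatter of two such steps. This shows agreement between two flat steps at a single level of the read-out; it does not show that the change would carry over to a core on which the chain or its terminal group moves the read-out, and two pairs make no rule for the series.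

Open, going by these compounds, is whether any group on the chain moves the read-out in this assay at all, for example a carboxylic acid or an amine at the chain end, or a longer chain than those among the four compounds. Also open, on these data alone, is whether a change elsewhere on the shared core, such as a hydroxyl group in place of a methoxy group, would shift the read-out and so give the chain variants a level at which they could be told apart.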